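This account rests on a few compounds, and the source may have more. Where it says the series, first, only, none or still open, it means among the compounds named here.

Compound 1 `ClCc1ccccc1Cn1cnc2c(Cl)nc(Cl)nc21` and compound 2 `ClCc1cccc(Cn2cnc3c(Cl)nc(Cl)nc32)c1` share the same atoms joined differently; the difference between the two cores is not broken down here. Compound 3 `Nc1nc(Cl)c2ncn(Cc3ccccc3CCl)c2n1` arises from compound 1 by amino in place of chloro on an aromatic carbon. In a functional assay on NCI-H460 cells (Homo sapiens) for cytotoxicity, read by sulforhodamine B assay, with a stated time of 48 h (a higher number here means that more compound is tolerated, a lower number that less compound is tolerated), compound 1 reaches only the limit of the assay, > 100000 nM. In this assay compound 2 likewise gives a limit, > 100000 nM. Compound 3 also returns a limit in this assay, > 100000 nM. The step from compound 1 to compound 3 is therefore one that the two limits leave unreadable, a step that the two limits leave unreadable from compound 1 to compound 3. What stands out is the limit of > 100000 nM in this assay, at which 3 of the 3 values shown sit, so none of the three compounds shows a measurable number.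

Compound 4 `Nc1nc(Cl)c2ncn(Cc3cccc(CCl)c3)c2n1` has not yet been measured in this assay. It differs from compound 2 by amino in place of chloro on an aromatic carbon, the same change as that from compound 1 to compound 3, at the same place. Since that earlier step could not be read, and since compound 2 itself sits at the limit, compound 4 is expected to give 100000 nM in this assay. The step from compound 2 to compound 4 is thus estimated as a number no higher from compound 2 to compound 4 (the limit leaves the size open), which rests only on the three limits already seen and on the unreadable earlier step. The estimate for compound 4 spans from 30000 nM to 300000 nM, with a strong chance that this assay again reports only a limit.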

Compound 4, concentration lethal to 50% of the cells: 47900 nM
Compound 4: the middle estimate sits 2.1-fold (0.32 log units) above what was measured, and the stated range covers the measured number.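

In this assay, amino in place of chloro on an aromatic carbon, between two ring nitrogen atoms, gives an at least 2.0-fold lower number from compound 2 to compound 4 (0.31 log units; beyond the scatter), and this is the only readable instance of the change among the compounds shown. On the core of compound 1 the same change leads to compound 3, which returns only a limit, > 100000 nM. The step to compound 3 therefore cannot be read, so the series shows a lower number on one core but does not show that the change carries over to the other core, and the step on the core of compound 2 gives only a bound rather than a full size, because its starting point is itself a limit: the limit of > 100000 nM in this assay, at which 3 of the 4 values shown sit.

The compounds shown leave open whether a methylamino or hydroxyl group at that same aromatic carbon would also bring the number in this assay below the limit, or whether this is seen only with amino. They also leave open how far the number of compound 4 depends on its chloromethyl group, for which a methyl or hydroxymethyl group in the same place would provide the direct comparison.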